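A few compounds are considered here, and "the series" means these few. Any claim that something is new, unique, unknown or untested is made for them only; others in the source may bear on it.

In a physicochemical assay for solubility, in phosphate buffer, with a stated time of 2 h, at pH 7.4 (on this read-out higher numbers stand for higher solubility and lower numbers for lower solubility), compound 1 (`Clc1ccc(Nc2nc(-c3ccccn3)c(Cl)s2)nc1`) gives only a limit, not a number: < 10000 nM. Compound 2 (`FC(F)(F)c1ccc(-c2nc(Nc3ccc(Cl)cn3)sc2Cl)nc1`) also gives only a limit: < 10000 nM. Compound 3 (`CCOc1ccc(-c2nc(Nc3ccc(Cl)cn3)sc2Cl)nc1`) likewise gives only a limit: < 10000 nM. All three therefore sit at one boundary, (the limit of < 10000 nM in this assay, at which 3 of the 3 values shown sit). Compound 4 (`Clc1ccc(Nc2nc(-c3cccnn3)c(Cl)s2)nc1`) carries pyridazin-3-yl in place of pyridin-2-yl on an aromatic carbon, (pyridazin-3-yl in place of pyridin-2-yl on an aromatic carbon). The nearest measured evidence is a step that the two limits leave unreadable from compound 1 to compound 2, together with a step that the two limits leave unreadable from compound 1 to compound 3 and a step that the two limits leave unreadable from compound 2 to compound 3, so these steps supply no size, and no shift beyond the scatter is expected in this assay. The expected change is a step that the limit leaves unreadable from compound 1 to compound 4. The estimate for compound 4 is 5000 nM, with an expected range of 1500 nM to 15000 nM.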

Compound 4, solubility: < 10000 nM
Compound 4 was reported as a limit; the forecaster's own chance of this, stated with the estimate: 75%; the middle value does not contradict the limit.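

The step from compound 1 to compound 4 cannot be read, because both values are limits and not numbers: the limit of < 10000 nM in this assay, at which 4 of the 4 values shown sit.

The compounds shown leave open the actual value of each compound, and so whether pyridazin-3-yl in place of pyridin-2-yl changes the read-out at all.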